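This account rests on a few compounds, and the source may have more. Where it says the series, first, only, none or still open, it means among the compounds named here.

Measured so far in an assay on U2OS cells for activation of nuclear factor erythroid 2-related factor 2 (Homo sapiens), read by beta-arrestin recruitment, with a stated time of 6 h; a lower number here means that less compound is needed, a higher number that more compound is needed for the effect:

compound 1, `O=S(=O)(/C=C/c1ccccn1)c1ccccc1Cl`: 618 nM
compound 2, `O=S(=O)(/C=C/c1ccccn1)c1cccc(Cl)c1`: 1430 nM
compound 3, `O=S(=O)(/C=C/c1cccnc1)c1ccccc1Cl`: 2850 nM

Compound 1 and compound 3 share a core and differ in one place: pyridin-3-yl in place of pyridin-2-yl on a double-bonded chain carbon bound to a double-bonded chain carbon. This change gave a 4.6-fold higher number from compound 1 to compound 3 (0.66 log units; beyond the scatter). Compound 2 carries a different core, and the difference between the two cores is not broken down here. In this assay compound 2 gives 1430 nM, a number beyond the scatter from that of compound 1, which gives 618 nM, while compound 3, with 2850 nM, lies within the scatter of compound 2, so the two cannot be put in order.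

Compound 4, `O=S(=O)(/C=C/c1cccnc1)c1cccc(Cl)c1`, is not yet measured. It stands to compound 2 as compound 3 stands to compound 1: pyridin-3-yl in place of pyridin-2-yl on a double-bonded chain carbon bound to a double-bonded chain carbon. The place is the same in both pairs, so this is the same change, seen once so far among the measured compounds.

Because this change gave a 4.6-fold higher number from compound 1 to compound 3 (0.66 log units; beyond the scatter), a step of about the same size is expected when it is applied to compound 2, namely a 4.5-fold higher number from compound 2 to compound 4 (0.66 log units; beyond the scatter). Among the measured compounds shown here, the estimate rests on a single observed step and on no other pair, so it carries the uncertainty of one example. Compound 4 is therefore expected to give about 6500 nM in this assay, with a range from 2500 nM to 16000 nM.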

Compound 4, half-maximal effective concentration: 3520 nM
Compound 4: the middle estimate sits 1.8-fold (0.27 log units) above what was measured; measured number inside the range.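

In this assay, pyridin-3-yl in place of pyridin-2-yl on a double-bonded chain carbon bound to a double-bonded chain carbon gave a 2.5-fold higher number from compound 2 to compound 4 (0.39 log units; beyond the scatter), so the change raised the number on the second core as it had on the first, and in both cases the step lies beyond the scatter. Among the compounds shown here, although the printed step on the core of compound 2 is the smaller of the two, the pairs do not support a real difference in size, and the change carried over from one core to the other as far as these compounds can tell: the same change on two cores in this assay, a 4.6-fold higher number (0.66 log units; beyond the scatter) from compound 1 to compound 3 and a 2.5-fold higher number (0.39 log units; beyond the scatter) from compound 2 to compound 4, 1.9-fold (0.27 log units) apart, within the scatter of two such steps This rests on only two cores and one assay, so it does not show that the step would keep its direction or size on any other core, nor does it explain why pyridin-2-yl gives the lower number in both pairs.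

The compounds shown leave open how pyridin-4-yl would compare with the two pyridinyl groups seen here on either core. They also leave open whether the same step would hold if the chlorine gave way to a methoxy group, a nitrile or a carboxylic acid.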